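The source may report more compounds than this note shows. Statements on the series, on what has been measured and on what is new or still open speak of the compounds shown alone.

Compound 3 `Nc1nc2c(c(-c3cc4ccccc4o3)cn2[C@@H]2O[C@H](CO)[C@@H](O)[C@H]2O)c(=O)[nH]1` carries 1-benzofuran-2-yl and an amino group on the shared core. In an ADME assay on BJ cells (Homo sapiens), read by MTT assay, with a stated time of 72 h (on this read-out higher numbers stand for weaker inhibition and lower numbers for stronger inhibition), compound 3 gives only a limit, > 100000 nM. Compound 1 `Nc1nc2c(c(-c3cccs3)cn2[C@@H]2O[C@H](CO)[C@@H](O)[C@H]2O)c(=O)[nH]1`, with thiophen-2-yl in place of the 1-benzofuran-2-yl, also reaches only a limit in this assay, > 100000 nM. Compound 2 `O=c1[nH]cnc2c1c(-c1cc3ccccc3o1)cn2[C@@H]1O[C@H](CO)[C@@H](O)[C@H]1O`, with hydrogen in place of the amino group, gives 62700 nM in this assay. The step that the two limits leave unreadable from compound 1 to compound 3 is therefore not readable, and the step of an at least 1.5-fold higher number from compound 2 to compound 3 (0.20 log units; that floor lies within the scatter) is read only as a floor. For the measured compounds named here, the position of compound 3 is thus fixed only by the limit of > 100000 nM in this assay, at which 2 of the 3 values shown sit, and no measured step bears directly on the change now considered. Compound 4 `Nc1nc2c(c(-c3ccccc3)cn2[C@@H]2O[C@H](CO)[C@@H](O)[C@H]2O)c(=O)[nH]1` differs from compound 3 by phenyl in place of 1-benzofuran-2-yl on an aromatic carbon. No measured exchange of one aryl group for another gives a readable size in this assay. With nothing to point elsewhere, no shift beyond the scatter is expected, a number no higher from compound 3 to compound 4 (the limit leaves the size open), and compound 4 is most likely to remain at the limit. The estimate for compound 4 in this assay is 100000 nM, within 40000 nM to 300000 nM.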

Compound 4, half-maximal inhibitory concentration: > 100000 nM
Compound 4: a limit, no number; the forecaster's own chance of this, stated with the estimate: 75%; the middle value lies on the limit itself.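

In this assay compound 4 gives only a limit (> 100000 nM), so its steps from compound 3 and from compound 1 cannot be read. The compounds shown leave open whether exchanging the aryl group among compound 1, compound 3 and compound 4 changes the value at all.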